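The source may report more compounds than this note shows. Statements on the series, on what has been measured and on what is new or still open speak of the compounds shown alone.

Compound 3 `N#CC1=C(N)Oc2c(N)cc3nc4ccccc4nc3c2C12C(=O)N(Cc1cnnn1-c1ccc([N+](=O)[O-])cc1[N+](=O)[O-])c1ccccc12` is the only one of the three measured analogues with a numerical result in an ADME assay on L02 cells (Homo sapiens) for antiproliferative activity, read by MTT assay, with a stated time of 48 h (a higher number here means a weaker inhibitor, a lower number a stronger inhibitor), where compound 3 gives 22800 nM. Compound 1 `COc1ccc(-n2nncc2CN2C(=O)C3(C(C#N)=C(N)Oc4c(N)cc5nc6ccccc6nc5c43)c3ccccc32)cc1` reaches only the limit of this assay, with > 50000 nM. Compound 2 `N#CC1=C(N)Oc2c(N)cc3nc4ccccc4nc3c2C12C(=O)N(Cc1cnnn1-c1cc(Cl)ccc1Cl)c1ccccc12` likewise stops at the limit, with > 50000 nM. The two steps onto compound 3 thus read an at least 2.1-fold lower number from compound 1 to compound 3 (0.34 log units; beyond the scatter) and an at least 2.1-fold lower number from compound 2 to compound 3 (0.34 log units; beyond the scatter), while a step that the two limits leave unreadable from compound 1 to compound 2 because of the limit of > 50000 nM in this assay, at which 2 of the 3 values shown sit. Compound 4 `N#CC1=C(N)Oc2c(N)cc3nc4ccccc4nc3c2C12C(=O)N(Cc1cnnn1-c1ccc(Cl)cc1[N+](=O)[O-])c1ccccc12` differs from compound 3 by chloro in place of nitro on an aromatic carbon. The step of an at least 2.1-fold lower number from compound 2 to compound 3 (0.34 log units; beyond the scatter) ran from a chloro-bearing ring to a dinitro ring, and compound 4 restores one chloro, so a partial return toward a higher number is expected, with a fair chance of reaching the limit again. Compound 4 is estimated at 35000 nM, within 15000 nM to 80000 nM. The expected step is a 1.5-fold higher number from compound 3 to compound 4 (0.19 log units; within the scatter).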

Compound 4, half-maximal inhibitory concentration: > 50000 nM
Compound 4: a limit, no number (the forecaster's own chance of this, stated with the estimate: 40%); middle value at least 1.4-fold (0.15 log units) away from the limit.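

In this assay, chloro in place of nitro on the aromatic carbon para to a large group gives an at least 2.1-fold higher number from compound 3 to compound 4 (0.34 log units; beyond the scatter), so among these compounds a measurable number appears only with the 2,4-dinitrophenyl group, and the single nitro left in the 4-chloro-2-nitrophenyl group does not provide one. On these data alone, the result for compound 4 is a limit, not a number, so the true size of this step stays open. The steps from compound 1 and compound 2 to compound 4 cannot be read: the limit of > 50000 nM in this assay, at which 3 of the 4 values shown sit.

As far as these compounds go, whether an amine or a carboxylic acid in place of this nitro would give a number remains open. From the compounds shown here alone, it is also open whether the other nitro of compound 3 matters as much as this one.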